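The compounds below may be only part of what the source reports. "The series", "measured", "known", "first", "only" and "open" are said of these compounds alone.

Three closely related compounds have been tested in a functional assay on the whole organism (artery, strain albino) with Rattus norvegicus as the target, with a stated time of 180 min, at a dose of 10 mg/kg by the oral route (on this read-out lower numbers stand for less inhibition and higher numbers for more inhibition at the one dose given (going by the name of the read-out)), and a fourth awaits the same measurement.

Compound 1, with the structure `CC1=C(C(=O)Nc2ccc(F)cc2)C(c2ccc([N+](=O)[O-])cc2)N=C(SCc2cccc(Cl)c2)N1`, gives 11.9% in this assay. Compound 2, with the structure `CC1=C(C(=O)Nc2ccc(F)cc2)C(c2ccc([N+](=O)[O-])cc2)N=C(SCc2ccc(Cl)cc2)N1`, gives 23.2%. The two differ in one place only: 4-chlorophenyl in place of 3-chlorophenyl on a saturated chain carbon bound to a sulfur. That single change produced a number 11.3 percentage points higher from compound 1 to compound 2 (beyond the scatter).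

Compound 3, with the structure `CC1=C(C(=O)Nc2ccc([N+](=O)[O-])cc2)C(c2ccc(Br)cc2)N=C(SCc2cccc(Cl)c2)N1`, gives 9.3%. Its core is not the same as the core of compound 1, and the difference between the two cores is not broken down here; the two values themselves lie within the scatter of each other.

Compound 4, with the structure `CC1=C(C(=O)Nc2ccc([N+](=O)[O-])cc2)C(c2ccc(Br)cc2)N=C(SCc2ccc(Cl)cc2)N1`, has not yet been measured. It stands to compound 3 exactly as compound 2 stands to compound 1: 4-chlorophenyl in place of 3-chlorophenyl on a saturated chain carbon bound to a sulfur. Because a number 11.3 percentage points higher from compound 1 to compound 2 (beyond the scatter) followed the same change in the same place, a step of similar size is expected, namely a number 9.7 percentage points higher from compound 3 to compound 4 (within the scatter). Going by the values given here, on that basis compound 4 is estimated at 19%, with a likely range from 8% to 30%; the one earlier example is the only support for this expectation.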

Compound 4, a percentage reported as inhibition, in the whole organism at one dose (the size of the read-out at that dose, not a potency): 19.1%
The estimate for compound 4 lay 0.1 percentage points below the measured number; the measured number falls inside the stated range.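

In this assay, exchanging 3-chlorophenyl for 4-chlorophenyl on the second core gives a number 9.8 percentage points higher from compound 3 to compound 4 (within the scatter), so this step alone cannot be told apart from the ordinary variation between repeated measurements. Set beside the earlier step, however, it points the same way and is of similar size, which suggests that the change carried over from one core to the other: the same change on two cores in this assay, a number 11.3 percentage points higher (beyond the scatter) from compound 1 to compound 2 and a number 9.8 percentage points higher (within the scatter) from compound 3 to compound 4, 1.5 percentage points apart, within the scatter of two such steps. Going by these compounds alone, this shows agreement between only two pairs of compounds at a single dose; it does not show that the change would behave alike on any other core, and it does not explain why the two steps agree.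

The compounds shown leave open what would happen if the chlorine of the 4-chlorobenzyl group gave way to a methoxy group or a carboxylic acid. They also leave open how the read-out would respond if a longer alkyl chain took the place of the whole benzyl group on the sulfur.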